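The source may report more compounds than this note shows. Statements on the series, on what has been measured and on what is new or still open speak of the compounds shown alone.

The series keeps one core and varies the group on a carbonyl carbon attached to a saturated ring carbon. Compound 1 `CCCn1c(=O)c2nc(C3CCC(C(=O)O)CC3)[nH]c2n(CCC)c1=O` carries the free acid; in a functional assay for antagonist activity at adenosine receptor A1 (Homo sapiens) (a higher number here means a weaker inhibitor, a lower number a stronger inhibitor), compound 1 gives 59 nM; 430 nM (2 entries), and the spread of those entries is recorded as the several entries of compound 1 in this assay, 59 nM; 430 nM (2 entries). Compound 3 `CCCn1c(=O)c2nc(C3CCC(C(=O)N(C)CCN(C)C)CC3)[nH]c2n(CCC)c1=O` carries a tertiary amide; in this assay compound 3 gives 17 nM; 85 nM (2 entries), its spread noted as the several entries of compound 3 in this assay, 17 nM; 85 nM (2 entries). Compound 2 `CCCn1c(=O)c2nc(C3CCC(C(=O)OC)CC3)[nH]c2n(CCC)c1=O`, the methyl ester, has a single number in this assay, where compound 2 gives 130 nM; two further entries for compound 2 carry no number. On the numbers shown compound 2 sits inside the span covered by the entries of compound 1 and compound 3, neither at the top nor the bottom of the set.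

Compound 4 `CCCNC(=O)C1CCC(c2nc3c(=O)n(CCC)c(=O)n(CCC)c3[nH]2)CC1` is the next member, not yet measured. The change from compound 2 is propylamino in place of methoxy on a carbonyl carbon; cut one bond further out, the same difference reads methoxycarbonyl to propylcarbamoyl. Going by the values given here, no measured pair isolates exactly that exchange. An amide is already present in compound 3, which gives 17 nM; 85 nM (2 entries), so a secondary amide in compound 4 is not expected to leave the range already seen. The step of a 1.6-fold lower number from compound 2 to compound 4 (0.21 log units; within the scatter) is expected to be small, at most toward somewhat stronger inhibition, and not clearly beyond the scatter. Compound 4 is expected to give 80 nM in this assay, with a range from 25 nM to 250 nM.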

Compound 4, inhibition constant: 85 nM
Estimate against measurement, compound 4: 1.1-fold (0.03 log units) below; the range from low to high includes it.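

In this assay, propylamino in place of methoxy on a carbonyl carbon gives a 1.5-fold lower number from compound 2 to compound 4 (0.18 log units; within the scatter). Going by these compounds alone, this is the first step that isolates one exchange at this place, and it shows that going from methoxycarbonyl to propylcarbamoyl, with a longer chain and an amide hydrogen entering, produces no change beyond the scatter. The reading rests on a single number for each of the two compounds, and repeat entries elsewhere in the series can lie well apart, so a small step here should be held loosely: the several entries of compound 1 in this assay, 59 nM; 430 nM (2 entries)

Still open, on these data alone, is whether a shorter or longer chain on the amide nitrogen, such as ethylamino or butylamino, or a ring-bearing group such as benzylamino, would also stay within the scatter of compound 4 at this carbonyl carbon. Whether the secondary amide of compound 4 and the tertiary amide of compound 3 differ also remains unsettled on these numbers, as the entries of compound 3 themselves span a wide range: the several entries of compound 3 in this assay, 17 nM; 85 nM (2 entries)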